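Fluorophenyl ureas of phenylethylamine: notes on the series

The source may report more compounds than this note shows. Statements on the series, on what has been measured and on what is new or still open speak of the compounds shown alone.

Measured so far:
- compound 1, `C[C@H](NC(=O)Nc1cccc(F)c1)c1ccccc1`: 94%
- compound 2, `C[C@@H](NC(=O)Nc1ccc(F)cc1)c1ccccc1`: 96%
- compound 3, `C[C@H](NC(=O)Nc1cccc(F)c1F)c1ccccc1`: 100%

All three were measured in an ADME assay on the whole organism with Oryza sativa as the target, tested at 1 uM; on this read-out lower numbers stand for a stronger effect and higher numbers for a weaker effect at the one concentration tested. Compound 1 gives 94%. Compound 2 gives 96%, the second highest of the three numbers, and its neighbours on either side lie within the scatter of it. Compound 3 gives 100%.

Compound 1 and compound 2 have the same atoms joined differently; the difference between the two cores is not broken down here. Compound 3 arises from compound 1 by fluoro in place of hydrogen on an aromatic carbon; this step gives a number 6 percentage points higher from compound 1 to compound 3 (within the scatter).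

Compound 4, `C[C@@H](NC(=O)Nc1ccc(F)c(F)c1)c1ccccc1`, is not yet measured. It arises from compound 2 by fluoro in place of hydrogen on an aromatic carbon. This is the same kind of change as that from compound 1 to compound 3, but not the same: in both the entering fluoro sits ortho to a fluoro group, yet in compound 3 it is ortho to a large group, whereas in compound 4 it is meta to a large group.

In this assay, the step from compound 2 to compound 4 is expected to be a number 2 percentage points higher from compound 2 to compound 4 (within the scatter), a change of about the size seen beside it in a number 6 percentage points higher from compound 1 to compound 3 (within the scatter), because compound 2 already gives 96% and little room remains upward. Compound 4 is thus estimated at 98%, between 91% and 100%.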

Compound 4, a percentage reported as activity, at one concentration (the size of the read-out at that concentration, not a potency): 99%
Compound 4: the middle estimate sits 1 percentage points below what was measured, within the range that was stated.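

In this assay, fluoro in place of hydrogen on an aromatic carbon, here ortho to a fluoro group and meta to a large group, gives a number 3 percentage points higher from compound 2 to compound 4 (within the scatter). Set beside the earlier step on the other core, the same change shows no difference that can be read between the two cores: the same change on two cores in this assay, a number 6 percentage points higher (within the scatter) from compound 1 to compound 3 and a number 3 percentage points higher (within the scatter) from compound 2 to compound 4, 3 percentage points apart, within the scatter of two such steps. This agrees with the change carrying from the core of compound 1 to the core of compound 2, but it rests on two pairs only, and since neither step leaves the scatter, it does not show that the added fluoro has an effect of its own on either core.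

Open, on these data alone, is whether any group other than fluoro on the aromatic ring, such as a methoxy group, an amine or a carboxylic acid, or a longer chain in place of the methyl group, would move the read-out beyond the scatter. Also open, as far as these compounds go, is how these compounds behave away from the single concentration tested, as a read-out at one concentration gives no potency.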